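Swapping Methyl for Bromo: What Should Change?

The source may report more compounds than this note shows. Statements on the series, on what has been measured and on what is new or still open speak of the compounds shown alone.

Measured in an ADME assay on cells (Astrocyte, Rattus norvegicus, strain Wistar) for inhibition, read by sulforhodamine B assay, with a stated time of 72 h; a lower number here means that less compound is tolerated, a higher number that more compound is tolerated:
- Compound 1 `CSc1ccc(C(=O)/C=C/c2ccc([N+](=O)[O-])o2)cc1`: 28400 nM
- Compound 2 `O=C(/C=C/c1ccc([N+](=O)[O-])o1)c1ccc(N2CCCC2)cc1`: 65800 nM
- Compound 3 `Cc1cccc(C(=O)/C=C/c2ccc([N+](=O)[O-])o2)c1`: 52200 nM

The value of compound 3 lies within the usual scatter of the values of both compound 1 and compound 2. Compound 4 `O=C(/C=C/c1ccc([N+](=O)[O-])o1)c1cccc(Br)c1` differs from compound 3 by one change: bromo in place of methyl on an aromatic carbon. Among the measured compounds shown here, the only measured step, a 2.3-fold higher number from compound 1 to compound 2 (0.36 log units; beyond the scatter), swaps two different groups, so it bears only loosely on this change. No measured compound carries bromo, so the data give no reason to expect a step beyond the scatter in this assay. The expected step is a 1.2-fold lower number from compound 3 to compound 4 (0.09 log units; within the scatter). Compound 4 is estimated at 42000 nM, with an expected range of 20000 nM to 85000 nM.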

Compound 4, half-maximal cytotoxic concentration: 35600 nM
Compound 4: middle estimate off by 1.2-fold (0.07 log units), on the high side; low and high end bracket the measured number.
By their numbers in this assay, from the lowest: compounds 1, 4, 3 and 2 (each within the scatter of the next, the first and the last beyond it).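

In this assay bromo in place of methyl on an aromatic carbon, meta to a large group, gives a 1.5-fold lower number from compound 3 to compound 4 (0.17 log units; within the scatter) and so stays within what repeat measurements would show. Among the compounds shown, compound 4 alone carries bromo, and it shows that this place takes bromo without a clear change in the number. Nothing available explains the size of this step. Going by these compounds, whether an amine, a carboxylic acid or a longer chain in this place would move the number stays open. So does whether bromo would behave the same on another aromatic carbon.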